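The source may hold more compounds than are shown below. What is called first, only, known or untested is meant among the compounds shown, and "the series" means these compounds.

Measured in an ADME assay on a cell-free system (plasma, Rattus norvegicus); on this read-out lower numbers stand for a smaller free fraction and higher numbers for a larger free fraction:
compound 1 `CC(=O)Nc1cc(-c2ccc(N(C)C(=O)c3c(F)cccc3Cl)c(N3CC4CC4C3)c2)n(C2CCC2)n1` — 0.0004
compound 2 `CC(C)n1nc(C(N)=O)cc1-c1ccc(N(C)C(=O)c2c(F)cccc2Cl)c(OCC(F)(F)F)c1` — 0.031
compound 3 `CC(=O)Nc1cc(-c2ccc(N(C)C(=O)c3c(Cl)cccc3Cl)c(N3CC4CC4C3)c2)n(C(C)C)n1` — 0.001

Compound 1 has the lowest unbound fraction of the three in this assay. Compound 3 comes nearest, its value beyond the scatter above compound 1; compound 2 lies furthest, far above compound 1.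

Compound 4 `CC(=O)Nc1cc(-c2ccc(N(C)C(=O)c3c(F)cccc3Cl)c(N3CC4CC4C3)c2)n(CC2CC2)n1` is not yet measured. It differs from compound 1 by cyclopropylmethyl in place of cyclobutyl on an aromatic nitrogen; the two have the same atoms, joined differently. For the measured compounds named here, no measured pair covers this change, so its size is unknown. Going by the values given here, with no step to rest on, the expectation is no change beyond the scatter: for compound 4 the estimated unbound fraction is 0.0005, range 0.0002 to 0.0012, meaning an expected step of a 1.3-fold higher number from compound 1 to compound 4 (0.10 log units; within the scatter).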

Compound 4, unbound fraction: 0.002
Compound 4: middle estimate off by 4.0-fold (0.60 log units), on the low side, outside the stated range (above it).
By their numbers in this assay, from the lowest: compound 1; then compounds 3 and 4 (each within the scatter of the next); then compound 2.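

The aromatic nitrogen position is sensitive in this assay: cyclopropylmethyl in place of cyclobutyl gives a 5.0-fold higher number from compound 1 to compound 4 (0.70 log units; beyond the scatter), although the two groups have the same heavy-atom count. For the compounds shown here, the unbound fraction therefore responds to how these carbons are joined, not only to how many there are, which the earlier compounds, differing in more than one place, could not show. Nothing available explains this step.

Still open, on these data alone, is how an amine, a carboxylic acid or a longer chain at this nitrogen would compare. Whether the step carries over to other substituents elsewhere on the shared core is also unknown.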